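From compound 2 to compound 3: the chain end

This account rests on a few compounds, and the source may have more. Where it says the series, first, only, none or still open, it means among the compounds named here.

Working notes on the series, with two compounds measured so far. In a functional assay on HL-60 cells (Homo sapiens) for antiproliferative activity, read by CCK-8 assay, with a stated time of 72 h (a lower number here means a stronger inhibitor, a higher number a weaker inhibitor), compound 1 (`Cc1ccc(/C=C(\C(=O)O)C(C)C)c2c1CC[C@H](C(C)(C)O)OC2=O`) reads > 100000 nM and this is a limit of the assay, not a number. For the measured compounds named here, compound 2 (`CC(=O)Oc1cc2c(CCC=C(C)C)c(C)ccc2cc1C(C)C`) gives 20800 nM as the only actual number in hand, so it stands as the sole quantitative anchor of the series.

The next compound is compound 3 (`CC(=O)Oc1cc2c(CC[C@H](O)C(C)(C)O)c(C)ccc2cc1C(C)C`) and it departs from compound 2 in one place only: 1,2-dihydroxy-2-methylpropyl in place of 2-methylprop-1-en-1-yl on a saturated chain carbon, two bonds along the chain from an aromatic carbon with 1,2-dihydroxy-2-methylpropyl replacing 2-methylprop-1-en-1-yl on a saturated chain carbon, two bonds along the chain from an aromatic carbon.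

Going by the values given here, no measured step between compounds differing in one place is available, so nothing calibrates this change. The expectation rests on compound 2 at 20800 nM and on the change itself. The expected step of a 1.9-fold higher number from compound 2 to compound 3 (0.28 log units; within the scatter) is estimated as a modest weakening, and it may not clear the usual scatter by much.

In this assay the value expected for compound 3 is 40000 nM with an estimated range from 14000 nM to 100000 nM and some expected chance of only a limit.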

Compound 3, half-maximal inhibitory concentration: 21700 nM
For compound 3 the middle estimate is 1.8-fold (0.27 log units) above the measured one, and the stated range covers the measured number.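

In this assay, for the compounds shown here, the first readable step at this place, on a saturated chain carbon, two bonds along the chain from an aromatic carbon, is a 1.0-fold higher number from compound 2 to compound 3 (0.02 log units; within the scatter), so putting 1,2-dihydroxy-2-methylpropyl in place of 2-methylprop-1-en-1-yl gives no difference that can be separated from the scatter. Going by these compounds alone, the chain end of compound 2 can therefore lose its double bond and take on hydrogen-bond donors, hydrogen-bond acceptors and a defined stereocentre with the read-out staying within the scatter, which the earlier compounds could not show. Compound 1 remains a limit of the assay rather than a number, and it offers no comparison for this step: the limit of > 100000 nM in this assay, at which 1 of the 3 values shown sits.

Open, from the compounds shown here alone, is whether the opposite configuration at the stereocentre of compound 3 would read alike, and whether a carboxylic acid or a primary amine at this chain end would stay at the same level. Also open, going by these compounds, is whether this result extends beyond this one pair, as a single step between compound 2 and compound 3 supports no wider rule for the series.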